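Cyanomethyl in place of carboxy on the side chain

A few compounds are considered here, and "the series" means these few. Any claim that something is new, unique, unknown or untested is made for them only; others in the source may bear on it.

- compound 1 `COc1ccc(-c2cc3c(OC)cc(OC)cc3n(CC#N)c2=O)cc1`: 10000 nM
- compound 2 `COc1ccc(-c2cc3c(OC)cc(OC)cc3n(CC(=O)O)c2=O)cc1`: 10000 nM

Both values come from a functional assay on U-87MG ATCC cells for cytotoxicity against U-87 MG (Homo sapiens), read by colorimetric assay and MTT assay; on this read-out higher numbers stand for weaker inhibition and lower numbers for stronger inhibition. Compound 1 stands level with compound 2 at 10000 nM. The unmeasured compound 3 `COc1ccc(-c2cc3c(OC)cc(OC)cc3n(CCC#N)c2=O)cc1` differs from compound 2 on a saturated chain carbon bound to an aromatic nitrogen, with cyanomethyl in place of carboxy on a saturated chain carbon bound to an aromatic nitrogen. Among the measured compounds shown here, the one measured step bearing on this change is no change at the digits printed from compound 1 to compound 2 (within the scatter), which lies within the scatter. In this assay the expected step is therefore no change at the digits printed from compound 2 to compound 3 (within the scatter), with none expected beyond the scatter in either direction. Compound 3 is estimated at 10000 nM, with an expected range of 4000 nM to 20000 nM.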

Compound 3, half-maximal inhibitory concentration: 10000 nM
Beside the measured number, compound 3's estimate shows no gap at the digits printed; the measured number falls inside the stated range.
By their numbers in this assay, from the lowest: compounds 1, 2 and 3 (each within the scatter of the next).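

In this assay the 2-cyanoethyl side chain gives the same reading as both earlier side chains, with no change at the digits printed from compound 2 to compound 3 (within the scatter) and with no change at the digits printed from compound 1 to compound 3 (within the scatter) as the two steps. On a saturated chain carbon bound to an aromatic nitrogen, these three side chains are therefore not separated by this read-out. Nothing available explains this result. As far as these compounds go, whether an amine, an amide or a longer chain at this place would depart from compound 3 at 10000 nM stays open. So does whether changes elsewhere on the shared core would shift the reading.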